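This account rests on a few compounds, and the source may have more. Where it says the series, first, only, none or still open, it means among the compounds named here.

Measured compounds:
compound 1, `C[C@@H](O)[C@H]1C(=O)N2C(C(=O)OCOC(=O)OC3CCCCC3)=C(S[C@@H]3CN[C@H](C(=O)Nc4cccc(C(=O)O)c4)C3)[C@H](C)[C@H]12`: 0%
compound 2, `C[C@@H](O)[C@H]1C(=O)N2C(C(=O)OCOC(=O)OC(C)(C)C)=C(S[C@@H]3CN[C@H](C(=O)Nc4cccc(C(=O)O)c4)C3)[C@H](C)[C@H]12`: 0%

In an ADME assay on a cell-free system (plasma, Rattus norvegicus) for metabolic stability, read by LC-MS, with a stated time of 60 min, at 37 degrees C, tested at 50 uM (a lower number here means that less of the compound is left, a higher number that more of the compound is left), compound 1 gives 0%, and in this assay compound 2 gives 0%. Compound 2 thus stands level with compound 1 at the digits shown, and the single measured step, no change at the digits printed from compound 1 to compound 2 (within the scatter), lies within the scatter: nothing of either compound was left after the stated time. Compound 3, `C[C@@H](O)[C@H]1C(=O)N2C(C(=O)OCOC(=O)OC(C)(C)C)=C(S[C@@H]3CN[C@H](C(=O)Nc4cccc(C(=O)OCOC(=O)OC(C)(C)C)c4)C3)[C@H](C)[C@H]12`, differs from compound 2 in one place, namely (((tert-butoxycarbonyl)oxy)methyl in place of hydrogen on an oxygen next to a carbonyl group). For the measured compounds named here, only one measured step bears on this move, no change at the digits printed from compound 1 to compound 2 (within the scatter), and it is the sole guide available. Since both measured compounds already sit at the floor of the read-out, a further change cannot push the number lower, and nothing measured points to a rise; compound 3 is therefore expected to show no change at the digits printed from compound 2 to compound 3 (within the scatter). Compound 3 is estimated at 0%, with a range from 0% to 8%.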

Compound 3, percent of the compound remaining: 8%
Compound 3: the middle estimate sits 8 percentage points below what was measured; the measured number falls inside the stated range.
By their numbers in this assay, from the lowest: compounds 1, 2 and 3 (each within the scatter of the next).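

In this assay, the ((tert-butoxycarbonyl)oxy)methyl group in place of hydrogen on an oxygen next to a carbonyl group gives a number 8 percentage points higher from compound 2 to compound 3 (within the scatter). For the compounds shown here, the earlier pair differed elsewhere, by tert-butyl in place of cyclohexyl, so this is the first measured change at this oxygen. Even with the hydroxy replaced by ((tert-butoxycarbonyl)oxy)methoxy, the step does not leave the scatter, so compound 3 cannot be told apart from compound 2 here.

As far as these compounds go, it remains open whether a plain methyl or ethyl group on this oxygen, or an amide in place of the carboxylic acid, would give a different reading. From the compounds shown here alone, it is also open whether a cyclohexyl carbonate on this same oxygen would read any differently. No measurement at hand accounts for the small difference seen between compound 2 and compound 3.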